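The source may report more compounds than this note shows. Statements on the series, on what has been measured and on what is new or still open speak of the compounds shown alone.

Three compounds have been measured in an assay on mitochondria from L6 cells (Rattus norvegicus) for activation, with a stated time of 90 min; on this read-out higher numbers stand for an effect only at larger amounts of compound and lower numbers for an effect already at smaller amounts:

compound 1 `Oc1nc2nonc2nc1Nc1cccc(F)c1`: 31200 nM
compound 2 `CCc1ccc(Nc2nc3nonc3nc2O)cc1`: 10700 nM
compound 3 `CCc1ccc(Nc2nc3nonc3nc2O)c(F)c1`: 6700 nM

Compound 1 stands highest of the three; compound 2 and compound 3 both give lower numbers than compound 1, and those gaps lie beyond the usual scatter. Compound 1 and compound 2 have different cores, and the difference between the two cores is not broken down here. Compound 2 and compound 3 differ in one place, (fluoro in place of hydrogen on an aromatic carbon), and this change gave a 1.6-fold lower number from compound 2 to compound 3 (0.20 log units; within the scatter).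

Compound 4 `Oc1nc2nonc2nc1Nc1cccc(F)c1F` has not yet been measured. It differs from compound 1 by fluoro in place of hydrogen on an aromatic carbon. This is the same kind of change as from compound 2 to compound 3, though the surroundings differ: in compound 4 the new fluoro is ortho to a fluoro group and ortho to a large group, while in compound 3 it is ortho to a large group and meta to an ethyl group. Because the change from compound 2 to compound 3 gave a 1.6-fold lower number from compound 2 to compound 3 (0.20 log units; within the scatter), a step of similar size, a 1.6-fold lower number from compound 1 to compound 4 (0.19 log units; within the scatter), is expected here. Compound 4 is therefore estimated at 20000 nM, with a likely range from 8000 nM to 50000 nM.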

Compound 4, half-maximal effective concentration: 9700 nM
Compound 4: middle estimate off by 2.1-fold (0.31 log units), on the high side; the measured number falls inside the stated range.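

In this assay, fluoro in place of hydrogen on an aromatic carbon gave a 3.2-fold lower number from compound 1 to compound 4 (0.51 log units; beyond the scatter). Set beside the same change on the other core, this step does not stand apart from the earlier one: the same change on two cores in this assay, a 1.6-fold lower number (0.20 log units; within the scatter) from compound 2 to compound 3 and a 3.2-fold lower number (0.51 log units; beyond the scatter) from compound 1 to compound 4, 2.0-fold (0.30 log units) apart, within the scatter of two such steps The change can therefore be carried between these two cores without a detectable difference in the size of its step, although only the step to compound 4 clears the scatter by itself; two pairs, with the new fluoro in different surroundings, do not show that the step would hold on a further core, and they give no reason for its size.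

The compounds shown leave open what a chloro, methyl or methoxy group, or an amine, would do in place of the new fluoro on the ring of compound 4. They also leave open whether an ethyl group added to the ring of compound 4 would change the number further.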